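The source may hold more compounds than are shown below. What is called first, only, known or untested is meant among the compounds shown, and "the series" means these compounds.

Measured in an ADME assay on Raji cells (Homo sapiens) for cytotoxicity, read by CellTiter-Glo and resazurin assay, with a stated time of 72 h; a lower number here means that less compound is needed, a higher number that more compound is needed for the effect:
- Compound 1 `Cc1nnc(-c2cccc(-c3ccc(C(=O)N(Cc4cccc(OCCCCCC(=O)O)c4)C(C)C)cc3)c2)o1`: > 26000 nM, a limit
- Compound 2 `COc1ccc(F)c(-c2ccc(C(=O)N(Cc3cccc(OCCCCCC(=O)O)c3)C(C)C)cc2)c1`: > 26000 nM, a limit

Compound 2 has no number in this assay, only the limit > 26000 nM. Going by the values given here, the series so far stands at the limit of > 26000 nM in this assay, at which 2 of the 2 values shown sit.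

Compound 3 `CC(C)N(Cc1cccc(OCCCCCC(=O)O)c1)C(=O)c1ccc(-c2cccc(Br)c2)cc1` carries 3-bromophenyl in place of 2-fluoro-5-methoxyphenyl on an aromatic carbon, para to a large group: 3-bromophenyl in place of 2-fluoro-5-methoxyphenyl on an aromatic carbon.

Among the compounds with values here, the only measured step that bears on this change is a step that the two limits leave unreadable from compound 1 to compound 2, which also exchanges the group on an aromatic carbon. It gives no size to carry over. No step beyond the scatter is therefore expected in this assay, and no direction can be assigned, because the limit of > 26000 nM in this assay, at which 2 of the 2 values shown sit, leaves only limits to work from. The expected step is a step that the limit leaves unreadable from compound 2 to compound 3, and a report as a limit is the likeliest outcome. For compound 3 the estimate is 30000 nM, with an expected range of 15000 nM to 60000 nM.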

Compound 3, half-maximal effective concentration: > 26000 nM
Compound 3: a limit, no number; the forecaster's own chance of this, stated with the estimate: 80%; the middle value is on the limit's open side.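

In this assay compound 3 gives > 26000 nM, a limit, so no step can be read among compound 1, compound 2 and compound 3: the limit of > 26000 nM in this assay, at which 3 of the 3 values shown sit.

Left open is whether exchanging the group on this aromatic carbon changes the read-out in this assay at all, and by how much.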